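The compounds below may be only part of what the source reports. "The series", "measured", "known", "first", "only" and "open" are said of these compounds alone.

Measured so far:
- compound 1, `CN(C)c1ccc(CNC(=O)Nc2cccc3cnccc23)cc1`: 157 nM
- compound 2, `O=C(NCc1ccc(N2CCCCCC2)c(F)c1)Nc1cccc2cnccc12`: 2.8 nM
- compound 3, `Cc1cc2c(NC(=O)NCc3ccc(N4CCCC4)c(F)c3)cccc2cn1`: 15.5 nM

In a functional assay for antagonist activity at transient receptor potential cation channel subfamily V member 1 (Homo sapiens), read by calcium flux (a lower number here means a stronger inhibitor, a higher number a weaker inhibitor), compound 3 gives 15.5 nM, the second highest of the three numbers. Compound 2 gives 2.8 nM, a lower number, and the gap to compound 3 is beyond the usual scatter. Compound 1 gives 157 nM, a higher number, and that gap too is beyond the scatter. Compound 3 therefore sits between the two, closer to compound 2.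

Compound 4, `Cc1cc2c(NC(=O)NCc3ccc(N4Cc5ccccc5C4)c(F)c3)cccc2cn1`, is the next compound to be measured in this assay. The change from compound 3 is a group of 9 heavy atoms (8 carbon, 1 nitrogen; one five-membered non-aromatic ring with 1 hetero atom, one six-membered aromatic ring of carbon only) in place of a group of 5 heavy atoms (4 carbon, 1 nitrogen; one five-membered non-aromatic ring with 1 hetero atom), on an aromatic carbon. Going by the values given here, no pair of measured compounds differs only in this way, so the step is untested. Compound 2 differs from compound 3 in more than one place, so its values cannot be tied to the change at hand. Even so, compound 2 gives 2.8 nM, a lower number, and this is the only hint available for the direction of the step. For compound 4 a modest move toward a lower number is expected, and the expected step is a 1.9-fold lower number from compound 3 to compound 4 (0.29 log units; within the scatter). Compound 4 is estimated at 8 nM, within a range from 2 nM to 40 nM.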

Compound 4, half-maximal inhibitory concentration: 7360 nM
Compound 4: middle estimate off by 920-fold (2.96 log units), on the low side; the measured number lies above the stated range.
By their numbers in this assay, from the lowest: compound 2; then compound 3; then compound 1; then compound 4.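

In this assay, putting the larger two-ring group in place of pyrrolidin-1-yl, on the aromatic carbon ortho to a fluoro group, gives a 470-fold higher number from compound 3 to compound 4 (2.68 log units; beyond the scatter) and so this position does not accept every ring joined through nitrogen. The step is large even though the two groups have the same counts of hydrogen-bond donors and acceptors and neither carries a net charge, so those counts alone do not foretell the outcome at this place. No measurement shown here accounts for the loss of activity.

As far as these compounds go, it remains open whether the added aromatic ring itself matters or the overall size of the group, as only this one replacement can be read. A piperidine or morpholine ring at this place would show how far the change can go before activity falls.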